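This account rests on a few compounds, and the source may have more. Where it says the series, first, only, none or still open, it means among the compounds named here.

Measured so far:
- compound 1 `C[Si](C)(C)C#Cc1cc(-c2nc3cc(F)ccc3s2)ccc1N` gives 210 nM in a functional assay on MDA-MB-468 cells (Homo sapiens) for inhibition, with a stated time of 72 h; on this read-out higher numbers stand for weaker inhibition of growth and lower numbers for stronger inhibition of growth
- compound 2 `N#Cc1cc(-c2nc3ccccc3s2)ccc1N` gives 340 nM in this assay

Compound 1 holds the lower of the two numbers in this assay, but its gap to compound 2 lies within the scatter, so the two cannot be ordered on these data. The two also differ in more than one place, so nothing is drawn from the pair about either change alone.

Compound 3 `C#Cc1cc(-c2nc3cc(F)ccc3s2)ccc1N` is the next compound to go into this assay. It differs from compound 1 in one place: a hydrogen atom in place of a group of 4 heavy atoms (3 carbon, 1 silicon; no ring), on a triple-bonded carbon. The shared core, the amine and the fluorine are kept.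

No measured step of this kind exists in the series, so the size of the change cannot be taken from a shown pair. With a hydrogen atom in place of the group of 4 heavy atoms on the triple-bonded carbon and the triple bond kept, the step is expected to be small, in neither direction beyond the scatter, a 1.2-fold higher number from compound 1 to compound 3 (0.08 log units; within the scatter). Compound 3 is therefore estimated at 250 nM, with a range from 80 nM to 800 nM.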

Compound 3, concentration for 50% growth inhibition: 6.8 nM
For compound 3 the middle estimate is 37-fold (1.57 log units) above the measured one, outside the stated range (below it).
By their numbers in this assay, from the lowest: compound 3; then compounds 1 and 2 (each within the scatter of the next).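

In this assay, the group on the triple-bonded carbon turns out to carry much of the growth-inhibition read-out: a hydrogen atom in place of the group of 4 heavy atoms (3 carbon, 1 silicon; no ring) gives a 31-fold lower number from compound 1 to compound 3 (1.49 log units; beyond the scatter) with the triple bond, the amine, the fluorine and the shared core all kept. Within the data shown here, this is the first single-place step, and it is large, which the earlier pair, differing in more than one place, could not show. Nothing at hand explains the size of this step.

Open, from the compounds shown here alone, is whether the lower number needs the hydrogen itself or would hold with a methyl or a cyclopropyl group on the triple-bonded carbon. The share of the fluorine also stays open, as no pair shown differs in the fluorine alone.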